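The source may report more compounds than this note shows. Statements on the series, on what has been measured and on what is new or still open speak of the compounds shown alone.

Going by the values given here, compound 2, `O=c1cc(-c2ccccc2)oc2cc(OCc3ccccc3)c(OCCCN3CCCCC3)c(O)c12`, carries the lower of the two numbers measured so far in a functional assay on HepG2 cells (Homo sapiens) for antiproliferative activity, read by MTT assay, with a stated time of 48 h (on this read-out lower numbers stand for stronger inhibition and higher numbers for weaker inhibition), with compound 2 giving 2200 nM. Among the compounds with values here, its only neighbour is compound 1, `O=c1cc(-c2ccccc2)oc2cc(O)c(OCCCN3CCCCC3)c(O)c12`, and in this assay compound 1 gives 70600 nM; the single measured step, a 32-fold lower number from compound 1 to compound 2 (1.51 log units; beyond the scatter), concerns a change on an oxygen and not on the amine.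

Compound 3, `CN1CCN(CCCOc2c(OCc3ccccc3)cc3oc(-c4ccccc4)cc(=O)c3c2O)CC1`, changes a different part of the molecule: 4-methylpiperazin-1-yl in place of piperidin-1-yl on a saturated chain carbon, three bonds along the chain from an oxygen on an aromatic ring. Within the data shown here, no measured pair here shows what this swap does, so the step from compound 1 to compound 2 offers no direct guide, and the expectation rests only on the unchanged remainder of compound 2. A change of this kind at the end of the chain is expected to move the number little, and the estimated step of a 1.4-fold higher number from compound 2 to compound 3 (0.13 log units; within the scatter) is taken to lie within or just outside the scatter. Compound 3 is therefore estimated at 3000 nM, in the range 1000 nM to 9000 nM.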

Compound 3, half-maximal inhibitory concentration: 2400 nM
Compound 3: middle estimate off by 1.3-fold (0.10 log units), on the high side, and the stated range covers the measured number.
By their numbers in this assay, from the lowest: compounds 2 and 3 (each within the scatter of the next); then compound 1.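

In this assay, putting 4-methylpiperazin-1-yl in place of piperidin-1-yl gives a 1.1-fold higher number from compound 2 to compound 3 (0.04 log units; within the scatter), so the two compounds cannot be told apart on this read-out. The earlier pair spoke only of a change on an oxygen, whereas this pair shows that, at this place on the chain, the ring at the end can take a second nitrogen and a methyl group with no difference beyond the scatter. No supporting evidence bears on this result, so it stands as an observation only.

Going by these compounds, whether morpholin-4-yl or a simple dimethylamino group at the chain end would also leave the number within the scatter remains open, as does the effect of a longer chain. Also open, on these data alone, is whether 4-methylpiperazin-1-yl would behave the same way with hydrogen in place of benzyl, as in compound 1.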